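Sulfonyl aryl exchange in an amide-to-sulfonamide series

A few compounds are considered here, and "the series" means these few. Any claim that something is new, unique, unknown or untested is made for them only; others in the source may bear on it.

Measured compounds in a functional assay on HL-60 cells (Homo sapiens) for antiproliferative activity, read by MTT assay, with a stated time of 72 h; a lower number here means a stronger inhibitor, a higher number a weaker inhibitor:
Compound 1, `CN(C(=O)c1ccc(F)cc1)c1ccc2[nH]c(-c3n[nH]c4ccccc34)cc2n1`: 1210 nM
Compound 2, `CN(C(=O)c1ccco1)c1ccc2[nH]c(-c3n[nH]c4ccccc34)cc2n1`: 4540 nM
Compound 3, `CN(c1ccc2[nH]c(-c3n[nH]c4ccccc34)cc2n1)S(=O)(=O)c1ccccc1`: 3700 nM

Compound 3 stands second highest of the three numbers. The step of a 3.1-fold higher number from compound 1 to compound 3 (0.49 log units; beyond the scatter) lies beyond the scatter, whereas the step of a 1.2-fold lower number from compound 2 to compound 3 (0.09 log units; within the scatter) lies within it, so compounds 2 and 3 are not separated. Compound 4, `COc1ccc(OC)c(S(=O)(=O)N(C)c2ccc3[nH]c(-c4n[nH]c5ccccc45)cc3n2)c1`, differs from compound 3 only in 2,5-dimethoxyphenyl in place of phenyl on a sulfonyl sulfur. Within the data shown here, no measured step alters the aryl group on the sulfonyl sulfur. The closest parallels are a 3.8-fold higher number from compound 1 to compound 2 (0.57 log units; beyond the scatter), an exchange of aryl groups on a carbonyl, and a 3.1-fold higher number from compound 1 to compound 3 (0.49 log units; beyond the scatter), both modest. A step of similar or smaller size, without a clear direction, is therefore expected, namely a 1.2-fold lower number from compound 3 to compound 4 (0.09 log units; within the scatter). Compound 4 is estimated at 3000 nM, with a range of 1200 nM to 8000 nM.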

Compound 4, half-maximal inhibitory concentration: 840 nM
For compound 4 the middle estimate is 3.6-fold (0.55 log units) above the measured one, outside the stated range (below it).
By their numbers in this assay, from the lowest: compounds 4 and 1 (each within the scatter of the next); then compounds 3 and 2 (each within the scatter of the next).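

In this assay the aryl group on the sulfonyl sulfur is not a silent site: 2,5-dimethoxyphenyl in place of phenyl gives a 4.4-fold lower number from compound 3 to compound 4 (0.64 log units; beyond the scatter) and this step lies beyond the scatter. Among these compounds, it is the first measured change at this position, and it separates the sulfonamide compound 4 from compound 3. Nothing available accounts for this step.

On these data alone, whether one methoxy group would suffice or both are needed stays open. So does the outcome of an amine or a carboxylic acid on this aryl ring.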